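Replacing the Fluorophenyl Arm with a Dimethoxyphenyl Group

The compounds below may be only part of what the source reports. "The series", "measured", "known", "first", "only" and "open" are said of these compounds alone.

Three compounds share one core and were measured in a functional assay on 143B cells (Homo sapiens) for inhibition, read by CCK-8 assay, with a stated time of 72 h, tested at 1 uM; on this read-out lower numbers stand for less inhibition and higher numbers for more inhibition at the one concentration tested (going by the name of the read-out). Compound 1 `Cc1cccc(N2C(=O)CSC2c2cccc(C(=O)NCCCCc3ccccc3)c2)c1` gives 71%. Compound 2 `CCN1C(=O)CSC1c1cccc(C(=O)NCCCCc2ccccc2)c1` gives 40%. Compound 3 `O=C(NCCCCc1ccccc1)c1cccc(C2SCC(=O)N2c2cccc(F)c2)c1` gives 63%, which is the second highest of the three numbers; its nearest neighbour is compound 1, whose value lies within the scatter of it, while compound 2 lies furthest away, beyond the scatter.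

The next compound, compound 4 `COc1ccc(N2C(=O)CSC2c2cccc(C(=O)NCCCCc3ccccc3)c2)c(OC)c1`, differs from compound 3 in one place: 2,4-dimethoxyphenyl in place of 3-fluorophenyl on an amide-type nitrogen in a ring

Among the measured compounds shown here, two measured steps bear on this change. The shift a number 31 percentage points lower from compound 1 to compound 2 (beyond the scatter) and the shift a number 23 percentage points higher from compound 2 to compound 3 (beyond the scatter) both show that a six-membered aromatic ring of carbon only on that ring nitrogen goes with clearly higher inhibition than ethyl. The shift a number 8 percentage points lower from compound 1 to compound 3 (within the scatter), by contrast, shows that exchanging one small substituent on that aromatic ring for another hardly moves the number. For the measured compounds named here, compound 4 keeps such an aromatic ring but carries two methoxy groups, a pattern no measured compound covers, so the account expects at most a change within the scatter in this assay. Compound 4 is therefore estimated at 60%, with a range from 42% to 76%, which means an expected step of a number 3 percentage points lower from compound 3 to compound 4 (within the scatter).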

Compound 4, a percentage reported as inhibition, at one concentration (the size of the read-out at that concentration, not a potency): 53%
Compound 4: middle estimate off by 7 percentage points, on the high side, and the stated range covers the measured number.
By their numbers in this assay, from the lowest: compound 2; then compounds 4, 3 and 1 (each within the scatter of the next, the first and the last beyond it).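

In this assay, the step of a number 10 percentage points lower from compound 3 to compound 4 (within the scatter) shows that the 2,4-dimethoxyphenyl group, the largest of the groups seen on this amide-type nitrogen and the only one with hydrogen-bond acceptors, can take the place of 3-fluorophenyl without a change beyond the scatter. The step of a number 13 percentage points higher from compound 2 to compound 4 (beyond the scatter) adds that this arm, like the 3-methylphenyl and 3-fluorophenyl arms, still stands clear of ethyl. Among the compounds shown here, the step of a number 18 percentage points lower from compound 1 to compound 4 (beyond the scatter) is the first exchange of one aromatic arm for another on this nitrogen to go beyond the scatter, so these arms are not all equivalent, although compound 3 lies within the scatter of both compound 1 and compound 4, and no measurement offered here accounts for the gap.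

Compound 4 carries both methoxy groups at once, so the compounds shown cannot tell whether either one alone would give the same number, as a phenyl ring with a single methoxy group might show. Also open, from the compounds shown here alone, is how an amine or a carboxylic acid on that aromatic ring would read, or a shorter chain in place of the four-carbon link to the terminal phenyl ring of the shared core.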